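Ethoxy to fluoro at the chain carbon

The source may report more compounds than this note shows. Statements on the series, on what has been measured and on what is new or still open speak of the compounds shown alone.

In a functional assay on HFF cells (Homo sapiens) for cytotoxicity (a lower number here means a stronger inhibitor, a higher number a weaker inhibitor), compound 3 `CCOC[C@H]1OC(n2c(Cl)nc3cc(Cl)c(Cl)cc32)[C@H](O)[C@@H]1O` gives 26000 nM. Compound 2 `COC[C@H]1OC(n2c(Cl)nc3cc(Cl)c(Cl)cc32)[C@H](O)[C@@H]1O` gives 32000 nM and compound 1 `CC(=O)OC1C(CF)OC(n2c(Cl)nc3cc(Cl)c(Cl)cc32)C1OC(C)=O` gives 32000 nM, so the three numbers lie within the scatter of one another.

Compound 4 `O[C@@H]1[C@@H](CF)OC(n2c(Cl)nc3cc(Cl)c(Cl)cc32)[C@@H]1O` is reached from compound 3 by one change: fluoro in place of ethoxy on a saturated chain carbon bound to a saturated ring carbon. In words, this is fluoro in place of ethoxy on a saturated chain carbon bound to a saturated ring carbon, or ethoxymethyl to fluoromethyl.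

Among the measured compounds shown here, the one measured step at this place is a 1.2-fold lower number from compound 2 to compound 3 (0.09 log units; within the scatter), and it stays within the scatter. Compound 1 also carries fluoromethyl, though it differs from compound 4 elsewhere too, and compound 1 gives 32000 nM. No measured change in the series goes beyond the scatter, so no step beyond it is expected in this assay, in either direction.

The expected step is a 1.2-fold higher number from compound 3 to compound 4 (0.06 log units; within the scatter). For compound 4 the estimated value is 30000 nM, with an expected range of 12000 nM to 75000 nM.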

Compound 4, half-maximal inhibitory concentration: 32000 nM
Beside the measured number, compound 4's estimate is 1.1-fold (0.03 log units) below it; measured number inside the range.
By their numbers in this assay, from the lowest: compounds 3, 1, 2 and 4 (each within the scatter of the next).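

In this assay, fluoro in place of ethoxy on a saturated chain carbon bound to a saturated ring carbon gives a 1.2-fold higher number from compound 3 to compound 4 (0.09 log units; within the scatter), and fluoro in place of methoxy at the same place gives no change at the digits printed from compound 2 to compound 4 (within the scatter). Until now only the ether had been lengthened at this position; these steps show that replacing the ether with fluoro, a single heavy atom without an oxygen, also stays within the scatter on the shared core. No other measurement available here bears on this flat result.

Still open, on these data alone, is whether a group of another kind at this chain carbon, such as an amine, a carboxylic acid or a hydroxyl, would give a step beyond the scatter. As far as these compounds go, a longer chain than ethoxy, such as butoxy, remains equally open.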